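Substituted aryl on the amide-type nitrogen of compound 2

The compounds below may be only part of what the source reports. "The series", "measured", "known", "first", "only" and "open" are said of these compounds alone.

Compound 2 `O=C(Nc1ccccc1)Nc1nc(Sc2c[nH]c3ccccc23)cc(N2CCN(c3ccccn3)CC2)n1` gives 19500 nM in a functional assay on MDA-MB-231 cells (Homo sapiens) for inhibition, with a stated time of 72 h (a higher number here means a weaker inhibitor, a lower number a stronger inhibitor), the second highest of the three numbers measured. Compound 1 `COc1ccc(NC(=O)Nc2nc(Sc3c[nH]c4ccccc34)cc(N3CCN(c4ccccn4)CC3)n2)cc1` gives 28400 nM in this assay, and compound 3 `O=C(Nc1ccccc1)Nc1nc(Sc2c[nH]c3ccccc23)cc(N2CCCCC2)n1` gives 8130 nM. The step of a 1.5-fold lower number from compound 1 to compound 2 (0.16 log units; within the scatter) changed the number little, whereas the step of a 2.4-fold lower number from compound 2 to compound 3 (0.38 log units; beyond the scatter) brought a modest gain. Compound 4 `Cc1cc(Cl)ccc1NC(=O)Nc1nc(Sc2c[nH]c3ccccc23)cc(N2CCN(c3ccccn3)CC2)n1` differs from compound 2 by 4-chloro-2-methylphenyl in place of phenyl on an amide-type nitrogen. For the measured compounds named here, of the measured steps, only the one from compound 1 to compound 2 touches this part of the molecule, and it stayed within the scatter; the step from compound 2 to compound 3 concerns another place and does not bear on the change. With one comparable step showing no movement, the expectation for compound 4 is a number close to that of compound 2, the step of a 1.2-fold lower number from compound 2 to compound 4 (0.09 log units; within the scatter) being expected to stay within the scatter. Compound 4 is therefore estimated at 16000 nM in this assay, with a range from 6000 nM to 45000 nM.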

Compound 4, half-maximal inhibitory concentration: 34700 nM
Beside the measured number, compound 4's estimate is 2.2-fold (0.34 log units) below it; the range from low to high includes it.
By their numbers in this assay, from the lowest: compound 3; then compounds 2, 1 and 4 (each within the scatter of the next).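

Two substituents on the aryl ring, chloro and methyl together, leave the number in this assay within the scatter, with a 1.8-fold higher number from compound 2 to compound 4 (0.25 log units; within the scatter) and, against the 4-methoxyphenyl analogue, a 1.2-fold higher number from compound 1 to compound 4 (0.09 log units; within the scatter). Until now this position had been probed only with a single methoxy group; across phenyl, 4-methoxyphenyl and 4-chloro-2-methylphenyl, the three compounds that carry the 4-(pyridin-2-yl)piperazin-1-yl group cannot be told apart in this assay. No supporting measurement is available to explain this insensitivity.

The compounds shown leave open whether the amide-type nitrogen would tolerate something other than a substituted phenyl, such as a cyclohexyl ring, a benzyl group or a phenyl bearing a carboxylic acid. They also leave open whether 4-chloro-2-methylphenyl would behave the same way alongside piperidin-1-yl, the group carried by compound 3.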